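Working notes: methyl ether to pyridine ester in one series

The compounds below may be only part of what the source reports. "The series", "measured", "known", "first", "only" and "open" are said of these compounds alone.

Among the compounds with values here, compound 1 `CC(C)=CCC[C@]1(C)[C@@H](CC=C(C)C)C[C@]2(CC=C(C)C)C(=O)[C@@](O)(CC=C(C)C)C(=O)[C@@]1(C(=O)C(C)C)C2=O` is the only member with a number: in an ADME assay on L6 cells (Rattus norvegicus) for cytotoxicity, with a stated time of 72 h (a higher number here means a weaker inhibitor, a lower number a stronger inhibitor), compound 1 gives 19700 nM. Within the data shown here, compound 2 `COC1=C(CC=C(C)C)C(=O)[C@@]2(C(=O)C(C)C)C(=O)[C@]1(CC=C(C)C)C[C@H](CC=C(C)C)[C@@]2(C)CCC=C(C)C` shares the core of compound 1, but in this assay compound 2 gives "not determined" (no result reported), no single value being reported, so compound 2 stands nowhere on the scale and no step can be drawn from it.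

Compound 3 `CC(C)=CCC[C@]1(C)[C@@H](CC=C(C)C)C[C@@]2(CC=C(C)C)C(=O)[C@]1(C(=O)C(C)C)C(=O)C(CC=C(C)C)=C2OC(=O)c1cccnc1` is the unmeasured analogue; it differs from compound 2 by (pyridin-3-yl)carbonyl in place of methyl on an oxygen on an unsaturated carbon. Among the measured compounds shown here, no measured step exists between this pair, and the series offers no other pair that differs in one place. The expectation for this assay is therefore a step of small size, in no clear direction, most likely none beyond the scatter. Compound 3 is expected at about 15000 nM in this assay, within an estimated range from 4000 nM to 60000 nM.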

Compound 3, half-maximal inhibitory concentration: 23900 nM
Beside the measured number, compound 3's estimate is 1.6-fold (0.20 log units) below it; low and high end bracket the measured number.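

Within the data shown here, with no single value for compound 2 in this assay, no step from compound 2 to compound 3 can be read. No evidence bears on this result. Still open, from the compounds shown here alone, is whether replacing methoxy with ((pyridin-3-yl)carbonyl)oxy on the shared core changes the read-out in this assay at all.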